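The source may hold more compounds than are shown below. What is called first, only, known or untested is meant among the compounds shown, and "the series" means these compounds.

Compound 1 `CCN(CC)C(=O)c1ccc(NC(=O)C(C)(O)C(F)(F)F)cc1` sits at the limit of an assay on a protein complex (Cavia porcellus) with sulfonylurea receptors; K-ATP channels (Homo sapiens) as the target; a lower number here means a stronger inhibitor, a higher number a weaker inhibitor: its reading of > 30000 nM is a limit of the assay, not a number. Compound 2 `CC(O)(C(=O)Nc1ccc([C@@H](O)c2ccccc2)cc1)C(F)(F)F` likewise gives only a limit, > 30000 nM. For the measured compounds named here, the one finite reading belongs to compound 3 `CCCN(CCC)S(=O)(=O)c1ccc(NC(=O)C(C)(O)C(F)(F)F)cc1`, which carries a sulfonamide where compound 1 carries an amide; in this assay compound 3 gives 6440 nM. Going by the values given here, the single measured step, from compound 1 to compound 2, is a step that the two limits leave unreadable from compound 1 to compound 2; both ends rest at the limit of > 30000 nM in this assay, at which 2 of the 3 values shown sit, so its size cannot be read.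

Compound 4 `CN(C)S(=O)(=O)c1ccc(NC(=O)C(C)(O)C(F)(F)F)cc1` differs from compound 1 by dimethylsulfamoyl in place of diethylcarbamoyl on an aromatic carbon. Among the compounds with values here, no measured step bears directly on this exchange: the step from compound 1 to compound 2 is unreadable, and the pair compound 1 and compound 3 compares a limit with a number. Within the data shown here, what the values do show is that compound 3, the only sulfonamide measured, is also the only compound returning a number, whereas the amide of compound 1 gives only a limit. On that basis compound 4 is expected near 20000 nM, within 5000 nM to 60000 nM, with a real chance of another limit. The estimate implies a step of an at least 1.5-fold lower number from compound 1 to compound 4 (0.17 log units; that floor lies within the scatter), towards stronger inhibition, read against a limit.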

Compound 4, half-maximal inhibitory concentration: 480 nM
Compound 4: the middle estimate sits 42-fold (1.62 log units) above what was measured; measured number below the stated range.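

At this place, on an aromatic carbon para to a large group, exchanging diethylcarbamoyl for dimethylsulfamoyl in this assay gives an at least 62-fold lower number from compound 1 to compound 4 (1.79 log units; beyond the scatter), and exchanging hydroxy(phenyl)methyl for the same group gives an at least 62-fold lower number from compound 2 to compound 4 (1.79 log units; beyond the scatter). Both steps start from a limit, so each gives a floor and not a full size: the limit of > 30000 nM in this assay, at which 2 of the 4 values shown sit. The series also now holds a pair of sulfonamides, and dimethylamino in place of dipropylamino on the sulfonyl sulfur gives a 13-fold lower number from compound 3 to compound 4 (1.13 log units; beyond the scatter), which shows that the reading at this place depends strongly on the groups on that nitrogen and not only on the presence of a sulfonyl group.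

Going by these compounds, it remains open how much of the gain over compound 1 follows the sulfonyl group and how much follows the shorter alkyl chains, a question that a dimethylcarbamoyl group at this place would separate and a diethylsulfamoyl group would narrow. Also open, on these data alone, is whether the trend from dipropylamino to dimethylamino continues to a methylamino group or a plain amino group on the sulfonyl sulfur, or holds for a cyclic amine such as piperidine.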